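This account rests on a few compounds, and the source may have more. Where it says the series, first, only, none or still open, it means among the compounds named here.

In a functional assay on MV4-11 cells (Homo sapiens) for inhibition, read by resazurin assay, with a stated time of 72 h (on this read-out lower numbers stand for stronger inhibition of growth and higher numbers for weaker inhibition of growth), compound 1 `O=Cc1ccc(-c2cncc(Cl)c2N2CCC3(CCNC3=O)CC2)o1` gives 5190 nM, compound 2 `CC(=O)c1ccc(-c2cncc(Cl)c2N2CCC3(CCNC3=O)CC2)s1` gives 1440 nM, and compound 3 `Cc1cc(-c2cncc(Cl)c2N2CCC3(CCNC3=O)CC2)sc1C=O` gives 2530 nM. Compound 3 has a lower number than compound 1 and cannot be told apart from compound 2: the gap a 1.8-fold higher number from compound 2 to compound 3 (0.24 log units; within the scatter) stays within the scatter, whereas a 2.1-fold lower number from compound 1 to compound 3 (0.31 log units; beyond the scatter) lies just beyond it. The still unmeasured compound 4 `O=Cc1cscc1-c1cncc(Cl)c1N1CCC2(CCNC2=O)CC1` brings one further change on the same aromatic carbon: 4-formylthiophen-3-yl in place of 5-formyl-4-methylthiophen-2-yl on an aromatic carbon. All three measured steps exchange the group at this place, and the largest of them, a 3.6-fold lower number from compound 1 to compound 2 (0.56 log units; beyond the scatter), is only modest. Among the compounds with values here, none of the measured compounds carries the 4-formylthiophen-3-yl group, so no direct comparison exists, and the direction of any shift remains open. On this assay, the expected outcome is therefore no shift clearly beyond the scatter, and the estimated step is a 1.2-fold higher number from compound 3 to compound 4 (0.07 log units; within the scatter). The estimated value for compound 4 is 3000 nM, with an expected range of 1200 nM to 7500 nM.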

Compound 4, concentration for 50% growth inhibition: 27100 nM
Compound 4: the middle estimate sits 9.0-fold (0.96 log units) below what was measured; the whole stated range lies below it.
By their numbers in this assay, from the lowest: compounds 2 and 3 (each within the scatter of the next); then compound 1; then compound 4.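

In this assay, this position proves far from indifferent to the group it carries: the 4-formylthiophen-3-yl group gives an 11-fold higher number from compound 3 to compound 4 (1.03 log units; beyond the scatter) and a 19-fold higher number from compound 2 to compound 4 (1.27 log units; beyond the scatter), both large, whereas the earlier exchanges were modest at most. Even against the 5-formylfuran-2-yl group, which had given the highest number so far, the change gives a 5.2-fold higher number from compound 1 to compound 4 (0.72 log units; beyond the scatter), leaving compound 4 with the highest number of the four. Both compound 3 and compound 4 carry a formyl group on a thiophene, so that feature alone does not keep the number low.

The compounds shown do not separate the loss of the methyl group from the change in how the thiophene is attached, and they leave open how an amine or a carboxylic acid in place of the formyl group would behave. Nothing available here accounts for the size of these steps.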